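Adding a Benzyloxy Group to Compound 2

A few compounds are considered here, and "the series" means these few. Any claim that something is new, unique, unknown or untested is made for them only; others in the source may bear on it.

Going by the values given here, compound 2 `O=c1c(Cc2coc3ccccc3c2=O)coc2ccccc12` gives 7400 nM in a functional assay on PC-3 cells (Homo sapiens) for antiproliferative activity, read by XTT assay (a lower number here means a stronger inhibitor, a higher number a weaker inhibitor), the higher of the two numbers measured so far; compound 1 `CC(C)COc1cccc2occ(Cc3coc4ccccc4c3=O)c(=O)c12` gives 1720 nM. Compound 3 `O=c1c(Cc2coc3cccc(OCc4ccccc4)c3c2=O)coc2ccccc12` differs from compound 2 by benzyloxy in place of hydrogen on an aromatic carbon. Among the compounds with values here, the one measured step that bears on this change is a 4.3-fold higher number from compound 1 to compound 2 (0.63 log units; beyond the scatter), where an isobutoxy group at that same place was removed. Putting a benzyloxy group back at that place is therefore expected to lower the number again, by a step on the order of a 6.2-fold lower number from compound 2 to compound 3 (0.79 log units; beyond the scatter). Compound 3 is thus expected to give about 1200 nM, within a range from 300 nM to 5000 nM.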

Compound 3, half-maximal inhibitory concentration: 4830 nM
Compound 3: middle estimate off by 4.0-fold (0.60 log units), on the low side; low and high end bracket the measured number.
By their numbers in this assay, from the lowest: compound 1; then compounds 3 and 2 (each within the scatter of the next).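

In this assay, benzyloxy in place of hydrogen gives a 1.5-fold lower number from compound 2 to compound 3 (0.19 log units; within the scatter), a change within the scatter, so adding a group at this place does not by itself secure a clear gain. The two groups also differ: phenyl in place of isopropyl gives a 2.8-fold higher number from compound 1 to compound 3 (0.45 log units; beyond the scatter), a step beyond the scatter, which shows that what sits on the oxygen matters. Nothing available explains this difference. The compounds shown leave open how a methoxy group, a longer alkyl chain or an amine would behave at this place.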